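This account rests on a few compounds, and the source may have more. Where it says the series, first, only, none or still open, it means among the compounds named here.

Working notes on the series. Compound 1 `CCCNC(=S)NNC(=O)Cn1c(=O)oc2ccc(C)cc21` in a functional assay on the whole organism for inhibition, with Mus musculus as the target, read by paw edema, with a stated time of 180 min, at a dose of 100 mg/kg by the oral route (a lower number here means a weaker effect, a higher number a stronger effect of the compound at the dose given), gives 46.1%. Compound 2 `CCNC(=S)NNC(=O)Cn1c(=O)oc2ccc(C)cc21` in this assay gives 36.3%. The one step measured so far, a number 9.8 percentage points lower from compound 1 to compound 2 (within the scatter), removes a methyl from the chain on the thiourea side and lies within the scatter, so the two numbers cannot be ordered with confidence; on the numbers shown, compound 2 sits at the low end of the pair, with compound 1 its only neighbour and the gap between them not beyond repeat variation.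

Compound 3 `CNC(=S)NNC(=O)Cn1c(=O)oc2ccc(C)cc21` continues the same shortening of that chain: hydrogen in place of methyl on a saturated chain carbon bound to an amide-type nitrogen. Among the measured compounds shown here, the only step that bears on it is a number 9.8 percentage points lower from compound 1 to compound 2 (within the scatter), the same kind of change one bond further out, and that step stayed within the scatter. Nothing in the two measured compounds points to a larger effect from removing the last chain methyl. The expected step is therefore a number 5.3 percentage points lower from compound 2 to compound 3 (within the scatter), small and not beyond the scatter, if anything toward a slightly weaker read-out. Compound 3 is estimated at 31% in this assay, with a range from 17% to 45%.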

Compound 3, a percentage reported as inhibition, in the whole organism at one dose (the size of the read-out at that dose, not a potency): 33.8%
Estimate against measurement, compound 3: 2.8 percentage points below, and the stated range covers the measured number.
By their numbers in this assay, from the lowest: compounds 3, 2 and 1 (each within the scatter of the next, the first and the last beyond it).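

With the step of a number 2.5 percentage points lower from compound 2 to compound 3 (within the scatter) the removal of this methyl stays inside the scatter of this assay, as the removal one bond further out did, so neither single change separates its two compounds. The wider comparison adds what the earlier pair could not show: the step of a number 12.3 percentage points lower from compound 1 to compound 3 (beyond the scatter) is the only modest difference in the series that lies beyond the scatter, so this place does respond to the length of the chain, while compound 2 cannot be separated from either neighbour. No evidence on the origin of this difference is available, and the observation holds for these three compounds alone.

As far as these compounds go, whether the read-out at this place would rise further with a longer chain such as butyl, and how it would respond to a cyclohexyl ring or a carboxylic acid in the same place, stays open. The three compounds also share one core, so whether the gap between compound 1 and compound 3 persists on another core cannot be told.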